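The source may hold more compounds than are shown below. What is called first, only, known or untested is meant among the compounds shown, and "the series" means these compounds.

The measured compounds in this series:

compound 1, `CC(=O)c1cccc(N/C(=N/O)c2ccc3occc3c2)c1`, with > 30000 nM in this assay
compound 2, `CCCCOc1cccc(N/C(=N/O)c2ccc3occc3c2)c1`, with > 30000 nM
compound 3, `O/N=C(/Nc1cccc(Oc2ccccc2)c1)c1ccc2occc2c1`, with > 30000 nM

In an assay on tissue (HeLa cells) for inhibition of Indoleamine 2,3-dioxygenase 1 (Homo sapiens), read by spectrophotometry (a higher number here means a weaker inhibitor, a lower number a stronger inhibitor), compound 3 gives > 30000 nM, which is a limit of the assay and not a number. Compound 1 gives > 30000 nM, likewise a limit. Compound 2 gives > 30000 nM, again a limit. All three therefore sit at the limit of > 30000 nM in this assay, at which 3 of the 3 values shown sit, and none of the three steps among them can be read: a step that the two limits leave unreadable from compound 1 to compound 2, a step that the two limits leave unreadable from compound 1 to compound 3 and a step that the two limits leave unreadable from compound 2 to compound 3 are each left unreadable by the two limits. Compound 3 thus stands at the limit together with compound 1 and compound 2, with no ordering among them.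

Compound 4, `O/N=C(/Nc1cccc(COc2ccccc2)c1)c1ccc2occc2c1`, differs from compound 3 by phenoxymethyl in place of phenoxy on an aromatic carbon. The measured steps that bear on this change, a step that the two limits leave unreadable from compound 1 to compound 3 and a step that the two limits leave unreadable from compound 2 to compound 3, are both unreadable, so they give neither a size nor a direction to expect in this assay. Since every compound shown sits at the limit, compound 4 is expected most likely to give only a limit as well. The estimate for compound 4 is 40000 nM, with a range from 12000 nM to 150000 nM. The step expected from this estimate is a step that the limit leaves unreadable from compound 3 to compound 4, which cannot be distinguished from none.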

Compound 4, half-maximal inhibitory concentration: > 30000 nM
Compound 4: only a limit was reported; the forecaster's own chance of this, stated with the estimate: 80%; the middle value lies beyond the limit too.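

In this assay compound 4 gives > 30000 nM, a limit of the assay and not a number, so its steps from compound 1, compound 2 and compound 3 cannot be read. The compounds shown leave open how they rank against one another, as all share one limit: the limit of > 30000 nM in this assay, at which 4 of the 4 values shown sit.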